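Benzyl methyl to methoxy: cytotoxicity outlook in the series

The source may report more compounds than this note shows. Statements on the series, on what has been measured and on what is new or still open speak of the compounds shown alone.

Measured so far:
Compound 1 `CS(=O)(=O)Nc1ccc2c(c1)S(=O)(=O)C=C(c1c(O)c3cc(F)ccc3n(Cc3ccc(F)c(Cl)c3)c1=O)N2` — in an ADME assay on 2209-23 cells (Homo sapiens) for cytotoxicity, read by WST assay (a higher number here means that more compound is tolerated, a lower number that less compound is tolerated), compound 1 gives only a limit, > 50000 nM.
Compound 2 `Cc1cc(Cn2c(=O)c(C3=CS(=O)(=O)c4cc(NS(C)(=O)=O)ccc4N3)c(O)c3cc(F)ccc32)ccc1F` — in this assay compound 2 gives only a limit, > 50000 nM.

Compound 2 therefore stands at the upper edge of what this assay reports, with no number of its own. For the measured compounds named here, the single measured step, a step that the two limits leave unreadable from compound 1 to compound 2, is unreadable because both values sit at the limit of > 50000 nM in this assay, at which 2 of the 2 values shown sit.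

Compound 3 `COc1cc(Cn2c(=O)c(C3=CS(=O)(=O)c4cc(NS(C)(=O)=O)ccc4N3)c(O)c3cc(F)ccc32)ccc1F` differs from compound 2 by methoxy in place of methyl on an aromatic carbon. Going by the values given here, no measured step bears on this change, and the one step recorded is itself unreadable, so the expectation rests only on the two limits. Compound 3 is expected to give 60000 nM, with a range from 30000 nM to 150000 nM. The expected step that the limit leaves unreadable from compound 2 to compound 3 is thus none beyond the scatter, most likely again reported as a limit.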

Compound 3, half-maximal cytotoxic concentration: > 50000 nM
Compound 3: no number, only a limit (the forecaster's own chance of this, stated with the estimate: 85%); the middle value does not contradict the limit.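

Compound 3 gives only a limit, so no step linking compound 3 with compound 2 or compound 1 can be read: the limit of > 50000 nM in this assay, at which 3 of the 3 values shown sit.

The compounds shown leave open whether chloro, methyl and methoxy differ at all in this assay: none of the three compounds has a number of its own.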